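The source may hold more compounds than are shown below. What is called first, only, known or untested is meant among the compounds shown, and "the series" means these compounds.

Measured so far in a functional assay on Gurav cells (Homo sapiens) for inhibition, read by sulforhodamine B assay; a lower number here means a stronger inhibitor of growth, a higher number a weaker inhibitor of growth:
- compound 1 `c1ccc(-c2ccc(-c3ccc(-c4nc5ccccc5[nH]4)cc3)cc2)cc1`: 100000 nM
- compound 2 `Cc1ccc2[nH]c(-c3ccc(-c4ccc(-c5ccc(N(C)C)cc5)cc4)cc3)nc2c1`: 6240 nM

Compound 1, at 100000 nM, holds the higher of the two numbers, and the gap down to compound 2 at 6240 nM lies beyond the scatter. These two compounds differ in more than one place, so the pair gives no measured effect for any single change. The series therefore has no direct guide for the next step.

The next compound to be measured in this assay is compound 3 `Fc1ccc(-c2ccc(-c3ccc(-c4nc5ccccc5[nH]4)cc3)cc2)cc1`. It is compound 1 with one change, fluoro in place of hydrogen on an aromatic carbon: phenyl becomes 4-fluorophenyl, with fluoro in place of hydrogen on an aromatic carbon, para to a large group. Within the data shown here, with so small a change and no single-place step to draw on, only a modest shift is expected. The expected change is a 1.7-fold lower number from compound 1 to compound 3 (0.22 log units; within the scatter), a slight move toward stronger growth inhibition that is not expected to exceed the scatter. For compound 3 the estimated value is 60000 nM, with an expected range of 15000 nM to 100000 nM.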

Compound 3, concentration for 50% growth inhibition: 100000 nM
The estimate for compound 3 lay 1.7-fold (0.22 log units) below the measured number, and the stated range covers the measured number.
By their numbers in this assay, from the lowest: compound 2; then compounds 1 and 3 (each within the scatter of the next).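

In this assay, among these compounds, the only single-place step, phenyl to 4-fluorophenyl, shows no change at the digits printed from compound 1 to compound 3 (within the scatter). The earlier pair could not show this: at this position, on an aromatic carbon para to a large group, fluoro in place of hydrogen does not separate the two compounds, so this single change does not bring the series any closer to the lower number of compound 2. No supporting measurement accompanies this result that could account for it.

Compound 2 still differs from compound 1 in more than one place, so the compounds shown do not reveal how much of that gap belongs to its dimethylamino group and how much to its methyl group, each of which would need to be read alone on the core of compound 1. Also open, on these data alone, is whether this position responds at all to a group larger or different in kind from fluoro, such as a carboxylic acid or a primary amine, since a single atom at one site says little about the site as a whole.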